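The source may report more compounds than this note shows. Statements on the series, on what has been measured and on what is new or still open speak of the compounds shown alone.

Measured in a functional assay with Oryctolagus cuniculus as the target; on this read-out lower numbers stand for stronger inhibition and higher numbers for weaker inhibition:

- Compound 1 `C/N=C(/NC)Nc1nc(-c2ccc(OC)cc2)c(-c2ccc(OC)cc2)s1` gives 970 nM
- Compound 2 `COc1ccc(-c2nc(CNC(C)=O)sc2-c2ccc(OC)cc2)cc1` gives 15 nM
- Compound 3 `COc1ccc(-c2nc(C(=O)N=C(N)N)sc2-c2ccc(OC)cc2)cc1` gives > 100 nM, which is a limit and not a number

Compound 3 therefore has no exact position on the scale, only its limit. The change followed here leads to compound 4 `COc1ccc(-c2nc(/C=C/C(=O)O)sc2-c2ccc(OC)cc2)cc1`, in which a 2-carboxyethenyl group takes the place of the chain of compound 3 on an aromatic carbon of a five-membered aromatic ring with 1 nitrogen and 1 sulfur: a group of 5 heavy atoms (3 carbon, 2 oxygen; no ring) in place of a group of 6 heavy atoms (2 carbon, 3 nitrogen, 1 oxygen; no ring), on an aromatic carbon.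

All three measured steps change the group on this same carbon. The data show a 65-fold lower number from compound 1 to compound 2 (1.81 log units; beyond the scatter), a large step, and an at least 6.6-fold higher number from compound 2 to compound 3 (0.82 log units; beyond the scatter), which is at least modest. The third, a step that the limit leaves unreadable from compound 1 to compound 3, gives no readable size. So the group here can move the number strongly, but none of these steps introduces 2-carboxyethenyl, and compound 3 offers only a limit as a starting point. No firm direction is therefore expected, and a step beyond the scatter cannot be predicted with confidence. The estimated step is a step that the limit leaves unreadable from compound 3 to compound 4. The expected range is wide, guided by compound 2 at 15 nM and compound 1 at 970 nM. For compound 4 the estimate is 150 nM, with an expected range from 25 nM to 900 nM.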

Compound 4, half-maximal inhibitory concentration: > 100 nM
Compound 4 gave a limit, no number; the forecaster's own chance of this, stated with the estimate: 25%; the middle value does not contradict the limit.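

In this assay, compound 4 gives > 100 nM, which is a limit and not a number. With 2-carboxyethenyl in place of acetamidomethyl on the aromatic carbon, the result is an at least 6.6-fold higher number from compound 2 to compound 4 (0.82 log units; beyond the scatter), so compound 4 joins compound 3 as a second compound whose group on this carbon does not hold the low number of compound 2. The steps from compound 3 to compound 4 and from compound 1 to compound 4 cannot be read, and compound 3 and compound 4 cannot be placed in order because both sit at the same limit: the limit of > 100 nM in this assay, at which 2 of the 4 values shown sit.

From the compounds shown here alone, how far the true values of compound 3 and compound 4 lie from that limit stays open. Going by these compounds, whether either of them compares with compound 1 at 970 nM stays open with it. On these data alone, it is also open whether an amine on a short chain, a saturated carboxylic acid chain or a longer amide chain on this carbon would come close to compound 2 at 15 nM.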